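Aryl amide to piperidine amide: clearance outlook

The compounds below may be only part of what the source reports. "The series", "measured", "known", "first", "only" and "open" are said of these compounds alone.

In an in vitro ADME assay on microsomes from liver (Homo sapiens) for pharmacokinetics, read by LC-MS, with a stated time of 10 min, tested at 1 uM (a lower number here means slower removal, a higher number faster removal of the compound), compound 1 (`Cc1ccc(NC(=O)[C@H]2CN(C)C[C@@H]2c2ccc(/C=C/C(=O)Nc3ccccc3N)cc2)cc1`) gives 15 mL/min/kg and compound 2 (`Cc1cc(NC(=O)[C@H]2CN(C)C[C@@H]2c2ccc(/C=C/C(=O)Nc3ccccc3N)cc2)ccc1F`) gives 15 mL/min/kg for the same core. Compound 3 (`CN1C[C@H](C(=O)Nc2ccc(Cl)cn2)[C@@H](c2ccc(/C=C/C(=O)Nc3ccccc3N)cc2)C1`) gives 13 mL/min/kg and stands level with both within the scatter. Compound 4 (`CN1C[C@H](C(=O)N2CCCCC2)[C@@H](c2ccc(/C=C/C(=O)Nc3ccccc3N)cc2)C1`) differs from compound 3 as follows (piperidin-1-yl in place of (5-chloropyridin-2-yl)amino on a carbonyl carbon), with piperidin-1-yl in place of (5-chloropyridin-2-yl)amino on a carbonyl carbon. The measured steps, no change at the digits printed from compound 1 to compound 2 (within the scatter) along with a 1.2-fold lower number from compound 1 to compound 3 (0.06 log units; within the scatter) and a 1.2-fold lower number from compound 2 to compound 3 (0.06 log units; within the scatter) as well, all swap a group on an amide-type nitrogen. None removes that nitrogen, so they bear only indirectly. Given their small size, no change beyond the scatter is expected in this assay here. The estimated step is a 1.2-fold higher number from compound 3 to compound 4 (0.06 log units; within the scatter) and no more. The estimate for compound 4 is 15 mL/min/kg (8 mL/min/kg to 28 mL/min/kg).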

Compound 4, clearance: 9 mL/min/kg
The estimate for compound 4 lay 1.7-fold (0.22 log units) above the measured number, and the stated range covers the measured number.
By their numbers in this assay, from the lowest: compounds 4, 3, 1 and 2 (each within the scatter of the next).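

Piperidin-1-yl on the carbonyl carbon removes the amide hydrogen and the aromatic ring together, yet in this assay all three new steps stay within the scatter: a 1.4-fold lower number from compound 3 to compound 4 (0.16 log units; within the scatter), a 1.7-fold lower number from compound 2 to compound 4 (0.22 log units; within the scatter) and a 1.7-fold lower number from compound 1 to compound 4 (0.22 log units; within the scatter). In this assay, then, the series shows no change beyond the scatter on leaving the aryl amides for this single non-aromatic amide. Nothing measured here bears on the cause of these numbers.

Compound 4 is the only non-aromatic amide shown, so the effect of a morpholin-4-yl group or of a piperidine ring carrying a carboxylic acid at this carbonyl carbon remains open.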